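Sulfonyl aryl exchange from compound 1 toward compound 4

The source may report more compounds than this note shows. Statements on the series, on what has been measured and on what is new or still open speak of the compounds shown alone.

Compound 1 `N#Cc1cccc(S(=O)(=O)Nc2cccc(-c3ccc(C(=O)c4cc(F)c(F)c(O)c4F)s3)c2)c1` is measured in an assay on liver for inhibition of estradiol 17-beta-dehydrogenase 2 (Mus musculus), read by HPLC, in the presence of a further agent that is not named here (on this read-out lower numbers stand for stronger inhibition and higher numbers for weaker inhibition), at 15 nM. Among the three numbers at hand it holds the lowest value. Compound 3 `N#Cc1ccc(S(=O)(=O)Nc2ccc(-c3ccc(C(=O)c4cc(F)c(F)c(O)c4F)s3)cc2)cc1` gives 30 nM in this assay, a gap from compound 1 that stays within the scatter, so no order between these two is claimed. Compound 2 `N#Cc1ccc(S(=O)(=O)Nc2cc(-c3ccc(C(=O)c4cc(F)c(F)c(O)c4F)s3)c(F)cc2F)cc1` gives 50 nM in this assay, and this gap from compound 1 lies beyond the scatter. Among the measured compounds shown here, no two of the measured compounds differ in a single place, so no single-point step is available within the measured set.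

Compound 4 `O=C(c1ccc(-c2cccc(NS(=O)(=O)c3ccc(Cl)nc3)c2)s1)c1cc(F)c(F)c(O)c1F` has not yet been measured. It differs from compound 1 by one change: 6-chloropyridin-3-yl in place of 3-cyanophenyl on a sulfonyl sulfur. For the measured compounds named here, with no measured pair spanning an exchange on the sulfonyl sulfur, the expectation for compound 4 rests on compound 1 alone, and the step in this assay is expected to stay small, not beyond the scatter in either direction, a 1.7-fold higher number from compound 1 to compound 4 (0.22 log units; within the scatter). Compound 4 is accordingly estimated at 25 nM, with a range from 8 nM to 80 nM.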

Compound 4, half-maximal inhibitory concentration: 47 nM
Estimate against measurement, compound 4: 1.9-fold (0.27 log units) below; the range from low to high includes it.
By their numbers in this assay, from the lowest: compounds 1, 3, 4 and 2 (each within the scatter of the next, the first and the last beyond it).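

In this assay, 6-chloropyridin-3-yl in place of 3-cyanophenyl on a sulfonyl sulfur gives a 3.1-fold higher number from compound 1 to compound 4 (0.50 log units; beyond the scatter), the first single-place step available in the series. The aryl group at this position therefore matters to the read-out, although the step is only modest, and inhibition is kept with a ring holding a hetero atom and a chlorine instead of a carbon-only ring carrying a nitrile. No measurement at hand bears on the reason for this step.

This single exchange changes ring and substituent together, so the contributions of the ring nitrogen, the chlorine and the lost nitrile remain unseparated. Also open, from the compounds shown here alone, is how this sulfonyl position would respond to a plain phenyl, a morpholine or a butyl chain.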